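Amine pendant swap on the spiro-pyrrolidine amide core

The source may report more compounds than this note shows. Statements on the series, on what has been measured and on what is new or still open speak of the compounds shown alone.

Measured compounds:
compound 1 `Cc1cccc(NC[C@@H]2CC3(CC3)CN2C(=O)c2nc(C)sc2-c2ccccc2)n1` 7.3
compound 2 `Cc1ccc(-c2ncccn2)c(C(=O)N2CC3(CC3)C[C@H]2CNc2ccc(C(F)(F)F)cn2)n1` 8.4
compound 3 `Cc1ccc(-n2nccn2)c(C(=O)N2CCC3(CC3)C[C@H]2CNc2cccc(C)n2)c1` 8.2

In a functional assay on CHO cells for antagonist activity at Orexin/Hypocretin receptor type 1 (Homo sapiens), read by FLIPR and calcium flux (a lower number here means a less potent compound, a higher number a more potent compound, by a factor of ten per unit of this negative logarithm), compound 1 stands lowest of the three numbers; compound 3 sits higher by an amount beyond the scatter, and compound 2 higher still, also beyond the scatter. For the measured compounds named here, no pair among the measured compounds differs in a single place, so no measured step guides the change to compound 4 `Cc1nc(C(=O)N2CC3(CC3)C[C@H]2CNc2ncc(Cl)cn2)c(-c2ccccc2)s1`. Compound 4 carries 5-chloropyrimidin-2-yl in place of 6-methylpyridin-2-yl on an amine nitrogen. Going by the values given here, with no direct precedent, the expected step of a number 0.50 log units higher from compound 1 to compound 4 (beyond the scatter) is a modest rise, but a result within the scatter of compound 1 cannot be excluded. Compound 4 is estimated at 7.8, with a range from 7.2 to 8.4.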

Compound 4, negative logarithm of the antagonist equilibrium constant: 6.8
The estimate for compound 4 lay 1.00 log units above the measured number; the measured number lies below the stated range.
By their numbers in this assay, from the lowest: compound 4; then compound 1; then compounds 3 and 2 (each within the scatter of the next).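

Placing 5-chloropyrimidin-2-yl in place of 6-methylpyridin-2-yl on the amine nitrogen gives, in this assay, a number 0.50 log units lower from compound 1 to compound 4 (beyond the scatter), the first reading at this position with the rest of the structure held constant. The number therefore responds to the ring carried on this nitrogen, even though both groups have the same heavy-atom count. Nothing measured here bears on why the number falls.

The swap changes the ring hetero atoms and the ring substituent together, so their separate contributions remain unresolved. A 5-chloropyridin-2-yl or 6-methylpyrimidin-2-yl group on the same nitrogen would separate them.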